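This account rests on a few compounds, and the source may have more. Where it says the series, first, only, none or still open, it means among the compounds named here.

Three analogues sharing one core have been run in an ADME assay on cells (Mus musculus, strain BALB/C) for cytotoxicity, read by MTT assay, with a stated time of 24 h; on this read-out lower numbers stand for higher toxicity in this test and higher numbers for lower toxicity in this test. Compound 1 `Cc1ccc(C(=O)N/N=C/c2ccccc2O)c(O)c1` gives 761000 nM in this assay, compound 2 `Cc1ccc(C(=O)N/N=C/c2ccc([N+](=O)[O-])cc2)c(O)c1` gives 734000 nM, and compound 3 `Cc1ccc(C(=O)N/N=C/c2ccc(Cl)cc2Cl)c(O)c1` gives 291000 nM. Compound 2 thus stands second highest of the three numbers; its nearest neighbour is compound 1, whose value lies within the usual scatter, while compound 3 sits furthest away, beyond the scatter. Compound 4 `COc1ccc(/C=N/NC(=O)c2ccc(C)cc2O)cc1` has not yet been measured. It differs from compound 2 in one place: methoxy in place of nitro on an aromatic carbon. Going by the values given here, no step between two measured compounds matches this change, so no shift beyond the scatter is expected in this assay. Compound 4 is expected at 650000 nM, with a range from 280000 nM to 1300000 nM. The expected step is a 1.1-fold lower number from compound 2 to compound 4 (0.05 log units; within the scatter).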

Compound 4, half-maximal cytotoxic concentration: 723000 nM
Estimate against measurement, compound 4: 1.1-fold (0.05 log units) below; the measured number falls inside the stated range.
By their numbers in this assay, from the lowest: compound 3; then compounds 4, 2 and 1 (each within the scatter of the next).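

In this assay, going by these compounds alone, methoxy in place of nitro on an aromatic carbon, para to a large group, gives a 1.0-fold lower number from compound 2 to compound 4 (0.01 log units; within the scatter) and is the only step here between measured compounds that differ in one place. At this position, exchanging nitro for methoxy therefore leaves the number within the scatter, even though the two groups differ in heavy atoms and hydrogen-bond acceptors. Going by these compounds, whether an amine, a carboxylic acid or a longer chain at this position would also stay within the scatter remains open. No available evidence explains this result.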